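A few compounds are considered here, and "the series" means these few. Any claim that something is new, unique, unknown or untested is made for them only; others in the source may bear on it.

Compound 1 `Cc1nsc2[nH]cnc12` and compound 2 `CSc1nc2c(C)nsc2[nH]1` were assessed in a functional assay on HFF cells (Homo sapiens) for inhibition; on this read-out lower numbers stand for stronger inhibition and higher numbers for weaker inhibition. In this assay compound 1 gives 32000 nM, and compound 2 gives 26000 nM. Within the data shown here, compound 2 thus holds the lower of the two numbers, but the only measured step, a 1.2-fold lower number from compound 1 to compound 2 (0.09 log units; within the scatter), lies within the scatter and so separates the two compounds in no reliable way.

Compound 3 `CSc1nc2cnsc2[nH]1` has not yet been measured. It differs from compound 2 as follows: hydrogen in place of methyl on an aromatic carbon. Among the measured compounds shown here, the single measured step concerns a methylsulfanyl in place of hydrogen at another aromatic carbon and leaves the methyl untouched, so no measured step bears directly on the present change. With nothing in the data pointing either way, compound 3 is expected to show a 1.2-fold higher number from compound 2 to compound 3 (0.06 log units; within the scatter), that is, no step beyond the scatter. Compound 3 is therefore estimated at 30000 nM, with a range from 10000 nM to 90000 nM.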

Compound 3, half-maximal inhibitory concentration: 32000 nM
For compound 3 the middle estimate is 1.1-fold (0.03 log units) below the measured one, and the stated range covers the measured number.
By their numbers in this assay, from the lowest: compounds 2, 1 and 3 (each within the scatter of the next).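

In this assay, hydrogen in place of methyl on the aromatic carbon next to the ring nitrogen gives a 1.2-fold higher number from compound 2 to compound 3 (0.09 log units; within the scatter), so this position, which the earlier step left untouched, now has a reading of its own: methyl and hydrogen cannot be told apart there. Alongside the methylsulfanyl step, a 1.2-fold lower number from compound 1 to compound 2 (0.09 log units; within the scatter), this means that neither single change shown moves the number beyond the scatter, and the three compounds cannot be ranked. Nothing measured here offers an explanation for this lack of separation.

Going by these compounds, whether an amine, a carboxylic acid or a longer chain on this aromatic carbon would shift the number beyond the scatter remains open. So does whether any such group would do so in place of the methylsulfanyl.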